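The source may report more compounds than this note shows. Statements on the series, on what has been measured and on what is new or still open speak of the compounds shown alone.

Compound 1 `COc1cc2c(Oc3ccc(NC(=O)c4cc(-c5ccccc5)ccn4)cc3F)ccnc2cc1OCCCN1CCCC1` is the reference point; in a functional assay on U-87MG ATCC cells (Homo sapiens) for cytotoxicity, read by MTT assay, with a stated time of 72 h (a lower number here means a stronger inhibitor, a higher number a weaker inhibitor), compound 1 gives 1010 nM. Compound 2 `COc1cc2c(Oc3ccc(NC(=O)c4cc(-c5ccc(F)cc5)ccn4)cc3F)ccnc2cc1OCCCN1CCCC1` carries the change (fluoro in place of hydrogen on an aromatic carbon); in this assay compound 2 gives 1780 nM, a step of a 1.8-fold higher number from compound 1 to compound 2 (0.25 log units; within the scatter). Compound 3 `COc1cc2c(Oc3ccc(NC(=O)c4nccc(-c5ccc(F)cc5)n4)cc3F)ccnc2cc1OCCCN1CCN(C)CC1` rests on a different core, and the difference between the two cores is not broken down here; in this assay compound 3 gives 910 nM. Compound 4 `COc1cc2c(Oc3ccc(NC(=O)c4nccc(-c5ccc(F)cc5F)n4)cc3F)ccnc2cc1OCCCN1CCN(C)CC1` is not yet measured and differs from compound 3 by fluoro in place of hydrogen on an aromatic carbon. This is the same kind of change as that made earlier, but the place is not the same: the earlier fluoro stands para to a large group, the new one ortho to a large group and meta to a fluoro group. The new step is expected to be about a 1.4-fold higher number from compound 3 to compound 4 (0.15 log units; within the scatter), resting on the earlier step of a 1.8-fold higher number from compound 1 to compound 2 (0.25 log units; within the scatter). Compound 4 is therefore estimated at 1300 nM in this assay, with a range from 500 nM to 3500 nM.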

Compound 4, half-maximal inhibitory concentration: 780 nM
The estimate for compound 4 lay 1.7-fold (0.22 log units) above the measured number; the range from low to high includes it.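

In this assay, turning 4-fluorophenyl into 2,4-difluorophenyl gives a 1.2-fold lower number from compound 3 to compound 4 (0.07 log units; within the scatter). Set beside the earlier fluoro step, this step cannot be told apart from it: the same change on two cores in this assay, a 1.8-fold higher number (0.25 log units; within the scatter) from compound 1 to compound 2 and a 1.2-fold lower number (0.07 log units; within the scatter) from compound 3 to compound 4, 2.1-fold (0.31 log units) apart, within the scatter of two such steps. Among these compounds, both steps therefore stay within the scatter on their own cores, but this does not show that the change carries over in a fixed way, since the fluoro stands in a different place in each step, and only two cores are compared.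

The compounds shown leave open whether a chloro, a methoxy group or an amine in place of the new fluoro would give a step beyond the scatter.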